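The source may report more compounds than this note shows. Statements on the series, on what has been measured and on what is new or still open speak of the compounds shown alone.

Compound 2 `CC(C)(C)CN(Cc1ccccc1C(F)(F)F)C(=O)C1CCN(S(=O)(=O)c2ccc3[nH]ncc3c2)CC1` gives 104% in a functional assay on CHO cells for positive allosteric modulation of muscarinic acetylcholine receptor M5 (Homo sapiens), read by calcium flux; a higher number here means a larger maximal response, a lower number a smaller maximal response. Among the compounds with values here, compound 1 `CCCN(Cc1ccccc1C(F)(F)F)C(=O)C1CCN(S(=O)(=O)c2ccc3[nH]ncc3c2)CC1` gives 94% in this assay; of the two numbers measured so far, compound 2 has the one that reads as the larger, but the step of a number 10 percentage points higher from compound 1 to compound 2 (within the scatter) lies within the scatter, so the two compounds cannot be told apart on this read-out. Compound 3 `O=C(C1CCN(S(=O)(=O)c2ccc3[nH]ncc3c2)CC1)N(Cc1ccccc1C(F)(F)F)CC1CC1` has not yet been measured. Its structure differs from compound 2 by cyclopropyl in place of tert-butyl on a saturated chain carbon bound to an amide-type nitrogen. Within the data shown here, the only measured step that bears on this position is the one in which tert-butyl replaced ethyl on a saturated chain carbon bound to an amide-type nitrogen, and it gave a number 10 percentage points higher from compound 1 to compound 2 (within the scatter). That exchange at the same position did not move the maximal response beyond the scatter, and the exchange of tert-butyl for cyclopropyl is of the same kind at the same place, so in this assay no step beyond the scatter is expected, with a number 5 percentage points lower from compound 2 to compound 3 (within the scatter) as the expected step. Compound 3 is therefore estimated at 99%, with an expected range from 84% to 114%.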

Compound 3, largest response reached (reported as percent of maximum), in percent of the reference or control that the assay uses: 102%
For compound 3 the middle estimate is 3 percentage points below the measured one, and the stated range covers the measured number.
By their numbers in this assay, from the lowest: compounds 1, 3 and 2 (each within the scatter of the next).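

In this assay, cyclopropyl in place of tert-butyl on a saturated chain carbon bound to an amide-type nitrogen gives a number 2 percentage points lower from compound 2 to compound 3 (within the scatter), and cyclopropyl in place of ethyl at the same place gives a number 8 percentage points higher from compound 1 to compound 3 (within the scatter), so all three compounds now stand within the scatter of one another. The earlier pair had only open carbon chains at this place; this result adds a three-membered non-aromatic ring of carbon only, and the maximal response still cannot be told apart from that of either open-chain compound. No measurement shown here gives a reason for this flat picture.

Every group shown at this place holds carbon only, with no hydrogen-bond donors or acceptors, so it stays open how an amine, a hydroxyl group or a carboxylic acid would read here, and the same goes for a longer chain or a phenyl ring. Because all these changes sit at this one place, the compounds also leave open whether changes elsewhere on the shared core would move the maximal response beyond the scatter.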